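Extending the amine chain and capping it with a sulfonamide

This account rests on a few compounds, and the source may have more. Where it says the series, first, only, none or still open, it means among the compounds named here.

Compound 3 `CC(C)(C)c1ccc(C(=O)N2CCC3(CC2)C(=O)N(CC(=O)NCCCN)CN3c2ccccc2)cc1`: 4200 nM
Compound 1 `CC(C)(C)c1ccc(C(=O)N2CCC3(CC2)C(=O)N(CC(=O)N2CCN(S(C)(=O)=O)CC2)CN3c2ccccc2)cc1`: 19000 nM
Compound 2 `CC(C)(C)c1ccc(C(=O)N2CCC3(CC2)C(=O)N(CC(=O)NCN)CN3c2ccccc2)cc1`: 26500 nM

All three compounds share one core and differ only in the group hanging from the side-chain carbonyl. In an assay on HEK293 cells for displacement of a labelled ligand from NPC1-like intracellular cholesterol transporter 1 (Homo sapiens) (a lower number here means a stronger inhibitor, a higher number a weaker inhibitor), compound 3 gives 4200 nM, the lowest number of the three; compound 1 gives 19000 nM and compound 2 gives 26500 nM. The step of a 6.3-fold lower number from compound 2 to compound 3 (0.80 log units; beyond the scatter) shows that lengthening the chain to a 3-aminopropyl group helped, and the step of a 4.5-fold lower number from compound 1 to compound 3 (0.66 log units; beyond the scatter) shows that compound 3 also beats the compound whose nitrogen carries a methylsulfonyl group.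

Compound 4 `CC(C)(C)c1ccc(C(=O)N2CCC3(CC2)C(=O)N(CC(=O)NCCCCCNS(C)(=O)=O)CN3c2ccccc2)cc1` has not been measured. It differs from compound 3 as follows: 2-(methanesulfonamido)ethyl in place of amino on a saturated chain carbon, three bonds along the chain from an amide-type nitrogen. The chain thus grows further, and its free amino group is replaced by a methanesulfonamide. For the measured compounds named here, compound 1, the only measured compound with a methylsulfonyl group on a nitrogen and no free amino group, gives 19000 nM, so the expectation is that compound 4 loses some of what compound 3 gained, with a 3.6-fold higher number from compound 3 to compound 4 (0.55 log units; beyond the scatter). Compound 4 is therefore estimated at 15000 nM, within a range of 4000 nM to 50000 nM.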

Compound 4, half-maximal inhibitory concentration: 5500 nM
For compound 4 the middle estimate is 2.7-fold (0.44 log units) above the measured one; low and high end bracket the measured number.
By their numbers in this assay, from the lowest: compounds 3 and 4 (each within the scatter of the next); then compounds 1 and 2 (each within the scatter of the next).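

Compound 4 ends its chain in a methanesulfonamide rather than a free amino group, yet the two compounds cannot be told apart (a 1.3-fold higher number from compound 3 to compound 4 (0.12 log units; within the scatter)), so among these compounds a free amino group at the chain end is not required for the lower numbers. A methylsulfonyl group on a nitrogen does not by itself bring a weak number either: a 3.5-fold lower number from compound 1 to compound 4 (0.54 log units; beyond the scatter), and compound 4 also keeps a clear margin over the short-chain amine, with a 4.8-fold lower number from compound 2 to compound 4 (0.68 log units; beyond the scatter). No measurement here explains these numbers.

Chain length and end group change together from compound 3 to compound 4, so their separate contributions remain unknown. Going by these compounds, a 5-aminopentyl chain with its free amine, or a 3-(methanesulfonamido)propyl chain, would separate them, and a carboxylic acid at the chain end remains open too.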